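Alkoxy variation on the thioether-linked dinitrile series

The source may report more compounds than this note shows. Statements on the series, on what has been measured and on what is new or still open speak of the compounds shown alone.

Measured compounds:
compound 1 `CCOc1ccc(-c2c(C#N)c(N)nc(SCc3ccn[nH]3)c2C#N)cc1` — 332 nM
compound 2 `CCOc1ccc(-c2c(C#N)c(N)nc(SCC(N)=O)c2C#N)cc1` — 38 nM
compound 3 `N#Cc1c(N)nc(SCc2ncc[nH]2)c(C#N)c1-c1ccc(OCC2CC2)cc1` — 9.5 nM

All three were run in a functional assay on CHO cells for agonist activity at adenosine receptor A2b (Homo sapiens), read by AlphaScreen and cAMP accumulation; a lower number here means that less compound is needed, a higher number that more compound is needed for the effect. Compound 3 gives the lowest number of the three; compound 2 is nearest to it and compound 1 furthest, both gaps beyond the scatter. Going by the values given here, the only step between compounds that differ in one place is an 8.7-fold lower number from compound 1 to compound 2 (0.94 log units; beyond the scatter), a change on the saturated chain carbon bound to a sulfur.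

Compound 4 `CCOc1ccc(-c2c(C#N)c(N)nc(SCc3ncc[nH]3)c2C#N)cc1` is not yet measured. It differs from compound 3 in one place: methyl in place of cyclopropyl on a saturated chain carbon bound to an oxygen on an aromatic ring. Among the compounds with values here, this change sits at the alkoxy side of the shared core, which none of the measured steps touches; compounds 1 and 2 carry the ethoxy group of compound 4 but differ from compound 3 at the sulfur-linked chain as well, so no single step speaks to the alkoxy change. In this assay a step of modest size, or none beyond the scatter, is expected, with the direction uncertain. For compound 4 the estimated value in this assay is 15 nM (range 5 nM to 45 nM). The step from compound 3 to compound 4 is thus expected to read a 1.6-fold higher number from compound 3 to compound 4 (0.20 log units; within the scatter).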

Compound 4, half-maximal effective concentration: 11.7 nM
The estimate for compound 4 lay 1.3-fold (0.11 log units) above the measured number; low and high end bracket the measured number.
By their numbers in this assay, from the lowest: compounds 3 and 4 (each within the scatter of the next); then compound 2; then compound 1.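

Cyclopropylmethoxy and ethoxy cannot be told apart in this assay (a 1.2-fold higher number from compound 3 to compound 4 (0.09 log units; within the scatter)), so removing the cyclopropyl ring in favour of methyl on the saturated chain carbon bound to an oxygen on an aromatic ring leaves no step beyond the scatter in this pair. Going by these compounds alone, compound 4 also supplies the first single-place readings for the 1H-imidazol-2-yl group with ethoxy held fixed, one against carbamoyl (a 3.2-fold lower number from compound 2 to compound 4 (0.51 log units; beyond the scatter)) and one against 1H-pyrazol-5-yl (a 28-fold lower number from compound 1 to compound 4 (1.45 log units; beyond the scatter)). Among the compounds shown, the steps beyond the scatter all lie on the saturated chain carbon bound to a sulfur, and the only step at the alkoxy side is within the scatter.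

On these data alone, it remains open whether this alkoxy side would stay as indifferent with a longer chain such as butoxy, or with a terminal amine or carboxylic acid, and whether the cyclopropylmethoxy to ethoxy result would carry over to compounds with carbamoyl or 1H-pyrazol-5-yl on the sulfur-linked chain. No supporting measurement is available to explain any of these steps.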